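The compounds below may be only part of what the source reports. "The series", "measured", "known", "first", "only" and "open" are said of these compounds alone.

Of the compounds shown here, three sharing one core have been tested in an ADME assay on MDBK cells (Bos taurus) for cytotoxicity, read by MTT assay, with a stated time of 96 h; on this read-out higher numbers stand for lower toxicity in this test and lower numbers for higher toxicity in this test. Going by the values given here, compound 1 `CN1CCN(CC(=O)Nc2ccc(-c3nc4cc(Cl)c(Cl)cc4[nH]3)cc2)CC1` gives 90000 nM, the only plain number among the three. Compound 2 `COc1ccc(-c2nc3cc([N+](=O)[O-])ccc3[nH]2)c(OC)c1OC` reaches only a limit of the assay, > 100000 nM. Compound 3 `CCC(=O)Nc1ccc(-c2nc3cc(C(F)(F)F)ccc3[nH]2)cc1` likewise sits at a limit, > 100000 nM. Among the compounds with values here, compound 1 thus stands as the one measured value, while the other two are summed up by the limit of > 100000 nM in this assay, at which 2 of the 3 values shown sit. Compound 4 `O=C(CN1CCCC1)Nc1ccc(-c2nc3cc(Cl)c(Cl)cc3[nH]2)cc1` differs from compound 1 in a single place: pyrrolidin-1-yl in place of 4-methylpiperazin-1-yl on a saturated chain carbon bound to a carbonyl carbon. Within the data shown here, no measured step of this kind exists among the three, so the expectation rests on compound 1 alone. The step from compound 1 to compound 4 is expected to be no change at the digits printed from compound 1 to compound 4 (within the scatter), a change no larger than the usual scatter. Compound 4 is therefore estimated at 90000 nM, between 45000 nM and 150000 nM.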

Compound 4, half-maximal cytotoxic concentration: 16000 nM
The estimate for compound 4 lay 5.6-fold (0.75 log units) above the measured number; measured number below the stated range.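

Pyrrolidin-1-yl in place of 4-methylpiperazin-1-yl, on a saturated chain carbon bound to a carbonyl carbon, gives a 5.6-fold lower number from compound 1 to compound 4 (0.75 log units; beyond the scatter) in this assay, which here means higher toxicity in this test. Going by these compounds alone, the earlier compounds offered no single-place comparison, so this is the first sign that the group at this place can move the read-out beyond the usual scatter. Nothing shown here explains the step.

Ring size and the number of ring nitrogens change together in this step, so their separate shares stay open. Piperidin-1-yl or morpholin-4-yl at this place could help to pull them apart.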